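One aromatic group exchanged on a shared core

A few compounds are considered here, and "the series" means these few. Any claim that something is new, unique, unknown or untested is made for them only; others in the source may bear on it.

Two compounds have been measured in a functional assay on MGC-803 cells (Homo sapiens) for antiproliferative activity, read by CCK-8 assay, with a stated time of 72 h, tested at 8 uM; a higher number here means a stronger effect of the compound at the concentration tested, a lower number a weaker effect:

Compound 1, `Nc1ccccc1NC(=O)c1ccc(CSC(=S)N2CCN(c3ccc(F)cc3)CC2)cc1`, gives 48.7%.
Compound 2, `Cc1ccc(N2CCN(C(=S)SCc3ccc(C(=O)Nc4ccccc4N)cc3)CC2)cc1`, gives 19.8%.

Among the compounds with values here, compound 2 stands lowest of these two numbers; the only neighbour is compound 1, and the step between them, a number 28.9 percentage points lower from compound 1 to compound 2 (beyond the scatter), is beyond the scatter and modest in size. Compound 3, `Nc1ccccc1NC(=O)c1ccc(CSC(=S)N2CCN(c3ncccn3)CC2)cc1`, differs from compound 2 in one place: pyrimidin-2-yl in place of 4-methylphenyl on an amine nitrogen in a ring. Within the data shown here, no measured step covers this kind of exchange; the single step known concerns a methyl in place of a fluoro, not the replacement of the whole aromatic group, so it gives only a weak hint that the ring on that nitrogen matters. With so little to go on, compound 3 is expected to land somewhere between the two measured numbers, and the expected step of a number 15.2 percentage points higher from compound 2 to compound 3 (beyond the scatter) is uncertain in direction. For compound 3 the estimate is 35%, with a range from 15% to 55%.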

Compound 3, a percentage reported as inhibition, at one concentration (the size of the read-out at that concentration, not a potency): 64.8%
For compound 3 the middle estimate is 29.8 percentage points below the measured one; the measured number lies above the stated range.
By their numbers in this assay, from the lowest: compound 2; then compound 1; then compound 3.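

In this assay the aromatic group on this ring nitrogen proves to matter far more than the methyl-for-fluoro exchange alone could show: pyrimidin-2-yl in place of 4-methylphenyl gives a number 45 percentage points higher from compound 2 to compound 3 (beyond the scatter), a large step. Pyrimidin-2-yl in place of 4-fluorophenyl also gives a number 16.1 percentage points higher from compound 1 to compound 3 (beyond the scatter), so compound 3 stands highest of the three, and an aromatic ring with 2 hetero atoms is accepted here in place of a ring of carbon only. No measurement at hand accounts for this gain.

Only one ring with hetero atoms is shown, so it stays open whether both ring nitrogens are needed for the higher number. A pyridin-2-yl group, with a single ring nitrogen, or an unsubstituted phenyl group at the same place would help to separate these possibilities.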